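Methylsulfanyl for methoxy on a naphthol inhibitor series

The source may report more compounds than this note shows. Statements on the series, on what has been measured and on what is new or still open speak of the compounds shown alone.

Measured compounds:
compound 1 `Oc1c(Cc2ccccn2)ccc2ccccc12` — 390 nM
compound 2 `Oc1c(Cc2cccnc2)ccc2ccccc12` — 230 nM
compound 3 `COc1ccc(Cc2ccc3ccccc3c2O)cc1` — 75 nM

All three share the same core and differ only in the ring carried on the linking chain. In an assay on RBL-1 cells with Polyunsaturated fatty acid 5-lipoxygenase (Rattus norvegicus) as the target (on this read-out lower numbers stand for stronger inhibition and higher numbers for weaker inhibition), compound 1 gives 390 nM. Swapping the ring position of the nitrogen gives a 1.7-fold lower number from compound 1 to compound 2 (0.23 log units; within the scatter). Compound 3 carries a methoxy-bearing carbon ring instead and gives 75 nM, the lowest of the three numbers; the gaps to compound 2 and to compound 1 both lie beyond the scatter.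

Compound 4 `CSc1ccc(Cc2ccc3ccccc3c2O)cc1` is the next step: methylsulfanyl in place of methoxy on an aromatic carbon. For the measured compounds named here, neither measured step touches this position, so nothing among the measured compounds indicates how replacing the oxygen-linked methyl by a sulfur-linked methyl will move the number in this assay. With no guide either way, the expectation is a step of no change at the digits printed from compound 3 to compound 4 (within the scatter), that is, no change beyond the scatter. Compound 4 is therefore estimated at 75 nM, with a range from 25 nM to 220 nM.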

Compound 4, half-maximal inhibitory concentration: 48 nM
Beside the measured number, compound 4's estimate is 1.6-fold (0.19 log units) above it; the measured number falls inside the stated range.
By their numbers in this assay, from the lowest: compounds 4 and 3 (each within the scatter of the next); then compounds 2 and 1 (each within the scatter of the next).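

In this assay, putting methylsulfanyl in place of methoxy gives a 1.6-fold lower number from compound 3 to compound 4 (0.19 log units; within the scatter), so the two compounds cannot be told apart on this read-out. The earlier step changed only the nitrogen position in the ring on the linking chain, whereas this one shows that, on an aromatic carbon para to a large group, the atom joining the methyl to the ring can be sulfur rather than oxygen with no change beyond the scatter. No measurement at hand bears on what lies behind this result.

The compounds shown leave open how an amine, a carboxylic acid or a longer chain such as ethoxy would read at this same place. They also leave open whether the same swap of oxygen for sulfur would give so small a step on a different core.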